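The compounds below may be only part of what the source reports. "The series", "measured", "known", "first", "only" and "open" are said of these compounds alone.

Values so far in a functional assay on MCF7 cells (Homo sapiens) for antiproliferative activity, read by MTT assay, with a stated time of 48 h; on this read-out lower numbers stand for stronger inhibition and higher numbers for weaker inhibition

compound 1 (`O=C(/C=C/c1ccc(F)cc1)Nc1nnc(-c2ccc(Br)cc2)s1`) 1.49 ug/mL
compound 2 (`O=C(/C=C/c1ccc(F)cc1)Nc1nnc(-c2ccccc2)s1`) 1.45 ug/mL
compound 3 (`O=C(/C=C/c1ccccc1)Nc1nnc(-c2ccc(Br)cc2)s1`) not yet measured

For the measured compounds named here, compound 1 stands level with compound 2 within the scatter, and the one measured step, a 1.0-fold lower number from compound 1 to compound 2 (0.01 log units; within the scatter), puts hydrogen in place of bromo on an aromatic carbon. Compound 3 carries a different change (hydrogen in place of fluoro on an aromatic carbon), hydrogen in place of fluoro on an aromatic carbon, read further out as 4-fluorophenyl to phenyl. Going by the values given here, no measured step covers this exchange directly, so the bromo step serves only as a loose guide. On that basis, no shift beyond the scatter is expected in this assay, and the expected step is a 1.1-fold higher number from compound 1 to compound 3 (0.03 log units; within the scatter) in size. For compound 3 the estimated value is 1.6 ug/mL with an expected range from 0.7 ug/mL to 3.8 ug/mL on this read-out.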

Compound 3, half-maximal inhibitory concentration: 1.5 ug/mL
Beside the measured number, compound 3's estimate is 1.1-fold (0.03 log units) above it, and the stated range covers the measured number.
By their numbers in this assay, from the lowest: compounds 2, 1 and 3 (each within the scatter of the next).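

In this assay, exchanging 4-fluorophenyl for phenyl gives a 1.0-fold higher number from compound 1 to compound 3 (0.00 log units; within the scatter) and so produces no shift beyond the scatter. For the compounds shown here, this adds a first reading at the fluoro position, which the earlier bromo exchange, a 1.0-fold lower number from compound 1 to compound 2 (0.01 log units; within the scatter), did not cover. On the core of compound 1, therefore, hydrogen can replace either halogen singly with the number staying level within the scatter, and no measurement shown here offers an explanation for this.

As far as these compounds go, it remains open whether a different group at this position, such as a methoxy group, an amine or a carboxylic acid, would move the number beyond the scatter. Also open, from the compounds shown here alone, is how a compound carrying hydrogen at both halogen positions would read.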